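Swapping methyl for ethoxy on the anilino ring of compound 1

A few compounds are considered here, and "the series" means these few. Any claim that something is new, unique, unknown or untested is made for them only; others in the source may bear on it.

Measured compounds:
- compound 1, `Cc1ccc(NC2=CC(=O)c3nc4n(c3C2=O)[C@H]2OC[C@@H](O)[C@H]2OC4)cc1`, 3480 nM
- compound 2, `CCOc1ccc(NC2=CC(=O)c3c(nc4n3[C@H]3OC[C@@H](O)[C@H]3OC4)C2=O)cc1`, > 4000 nM
- compound 3, `O=C1C(NC2CCCC2)=CC(=O)c2c1nc1n2[C@H]2OC[C@@H](O)[C@H]2OC1`, > 16000 nM

Within the data shown here, in a functional assay on ECa-109 cells for inhibition, with ECa-109 cell line (Homo sapiens) as the target, read by sulforhodamine B assay (on this read-out higher numbers stand for weaker inhibition and lower numbers for stronger inhibition), compound 1 gives 3480 nM, the only actual number among the three results. For compound 2 this assay reports only a limit, > 4000 nM. For compound 3 the result is likewise a limit, > 16000 nM. Among the measured compounds shown here, the one change that can be traced between measured compounds, a step that the two limits leave unreadable from compound 2 to compound 3, cannot be read in size, as the limit of > 16000 nM in this assay, at which 1 of the 3 values shown sits, and the limit of > 4000 nM in this assay, at which 1 of the 3 values shown sits, show.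

Compound 4, `CCOc1ccc(NC2=CC(=O)c3nc4n(c3C2=O)[C@H]2OC[C@@H](O)[C@H]2OC4)cc1`, has not yet been tested. It differs from compound 1 by ethoxy in place of methyl on an aromatic carbon. Compound 2 carries the same 4-ethoxyphenyl on its amine nitrogen, though on a differently joined core, and reaches only the limit (the limit of > 4000 nM in this assay, at which 1 of the 3 values shown sits). That is the only pointer available, and it is weak: it hints that the ethoxy bearer may be at or beyond the upper limit rather than clearly stronger than compound 1. Compound 4 is therefore expected to be no stronger than compound 1, with an expected step of a 1.6-fold higher number from compound 1 to compound 4 (0.20 log units; within the scatter). The estimate for compound 4 in this assay is 5500 nM, between 2000 nM and 16000 nM.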

Compound 4, half-maximal inhibitory concentration: 3210 nM
Compound 4: the middle estimate sits 1.7-fold (0.23 log units) above what was measured; low and high end bracket the measured number.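

In this assay, among these compounds, putting ethoxy in place of methyl on the aromatic carbon, para to a large group, gives a 1.1-fold lower number from compound 1 to compound 4 (0.04 log units; within the scatter), the first step in this set that can be read as a size. At this position of the shared core, then, 4-methylphenyl and 4-ethoxyphenyl cannot be told apart, even though the entering group has 3 heavy atoms against 1 and brings a hydrogen-bond acceptor that methyl lacks. Nothing measured here explains why the two groups read alike.

The compounds shown leave open whether this tolerance extends to groups of a different kind at the same place, such as a longer chain like butoxy, an amine or a carboxylic acid, since methyl and ethoxy alone give only a narrow view of the position. The step from compound 2 to compound 3 cannot be read because both values are limits, so how cyclopentyl on the amine nitrogen compares with 4-ethoxyphenyl also stays unsettled.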